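Swapping the Aryl Ring of Compound 3

A few compounds are considered here, and "the series" means these few. Any claim that something is new, unique, unknown or untested is made for them only; others in the source may bear on it.

Of the compounds shown here, three have so far been tested in a functional assay on HepG2 cells (Homo sapiens) for cytotoxicity, with a stated time of 72 h; a lower number here means a stronger inhibitor, a higher number a weaker inhibitor. Compound 1 `C=CCc1cc(C(C)=O)ccc1OCC=C(C)C` gives 14700 nM, compound 2 `C=CCOc1ccc(C=O)cc1OC` gives 10500 nM, and compound 3 `C#CCOc1ccc(/C=C/C(=O)c2ccccc2C)cc1OC` gives 2640 nM. Compound 3 stands lowest of the three and is thus the strongest inhibitor shown; its nearest neighbour is compound 2 and its furthest is compound 1, and both of those gaps lie beyond the scatter. The three compounds differ in many places at once, so no single change can be tied to these gaps.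

Compound 4 `C#CCOc1ccc(/C=C/C(=O)c2cccc(OC)c2)cc1OC` has not yet been measured. It differs from compound 3 in one place: 3-methoxyphenyl in place of 2-methylphenyl on a carbonyl carbon. The ring that leaves and the ring that enters are each one six-membered aromatic ring of carbon only; the entering 3-methoxyphenyl brings one oxygen and one hydrogen-bond acceptor, where the leaving 2-methylphenyl had none. Nothing measured here shows how such a swap shifts the number in this assay, so no step can be read off. The expected step, a 1.1-fold higher number from compound 3 to compound 4 (0.06 log units; within the scatter), is small, within the usual scatter in either direction. Compound 4 is therefore estimated at 3000 nM in this assay, with a range from 1000 nM to 9000 nM.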

Compound 4, half-maximal inhibitory concentration: 5540 nM
Compound 4: the middle estimate sits 1.8-fold (0.27 log units) below what was measured; low and high end bracket the measured number.
By their numbers in this assay, from the lowest: compound 3; then compounds 4, 2 and 1 (each within the scatter of the next, the first and the last beyond it).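

Replacing 2-methylphenyl with 3-methoxyphenyl on the carbonyl carbon gives a 2.1-fold higher number from compound 3 to compound 4 (0.32 log units; beyond the scatter) in this assay, a modest step. Going by these compounds alone, this is the first measured pair that differs in one place, and it shows that the aryl group on the carbonyl carbon can shift the number, with 2-methylphenyl the better of these two groups here. The swap alters the ring's substituent and, as the two names show, its numbered place, while also adding one oxygen and one hydrogen-bond acceptor, and no measurement shown explains why the number moved.

Still open, as far as these compounds go, is whether 3-methylphenyl or 2-methoxyphenyl on the same carbonyl carbon would stand closer to compound 3 or to compound 4, a comparison that could separate the choice of methyl or methoxy from the numbered place on the ring. Also unresolved is how an unsubstituted phenyl, or an aryl ring carrying an amine or a carboxylic acid, would change the number in this assay.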